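The source may hold more compounds than are shown below. What is called first, only, known or untested is meant among the compounds shown, and "the series" means these compounds.

Measured in an ADME assay on FSCLL cells (Homo sapiens) for cytotoxicity, read by MTT assay, with a stated time of 24 h; on this read-out higher numbers stand for lower toxicity in this test and lower numbers for higher toxicity in this test:
- compound 1 `CCC[C@H](N)C(=O)N[C@@H](CC(C)C)B(O)O`: 1100 nM
- compound 2 `CC(C)C[C@H](NC(=O)[C@@H](N)[C@@H](C)O)B(O)O`: 2500 nM
- compound 3 `CC(C)C[C@H](NC(=O)CN)B(O)O`: 670 nM

Not yet measured: compound 4 `CCCC[C@H](N)C(=O)N[C@@H](CC(C)C)B(O)O`.

Compound 3 gives 670 nM in this assay. Going by the values given here, that number cannot be told apart from the one for compound 1, but it stands clear of the one for compound 2. Compound 4 puts butyl in place of hydrogen on a saturated chain carbon bound to an amine nitrogen and a carbonyl carbon.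

Two measured steps change this same place. The closer guide is the propyl of compound 1, since propyl and butyl are both plain chains. Its loss gave a 1.6-fold lower number from compound 1 to compound 3 (0.22 log units; within the scatter), so that pair offers no clear direction. The loss of 1-hydroxyethyl gave a 3.7-fold lower number from compound 2 to compound 3 (0.57 log units; beyond the scatter), a modest step, but that group is a different kind of chain from butyl and is a weaker guide. Taken together, these steps suggest at most a small rise in the number in this assay. The estimated step is a 1.5-fold higher number from compound 3 to compound 4 (0.17 log units; within the scatter), so no clear change is expected. For compound 4 the expected value is 1000 nM, with an estimated range of 400 nM to 2500 nM.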

Compound 4, half-maximal cytotoxic concentration: 950 nM
Beside the measured number, compound 4's estimate is 1.1-fold (0.02 log units) above it; the measured number falls inside the stated range.
By their numbers in this assay, from the lowest: compounds 3, 4 and 1 (each within the scatter of the next); then compound 2.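

In this assay the step of a 1.4-fold higher number from compound 3 to compound 4 (0.15 log units; within the scatter) for butyl in place of hydrogen lies within the scatter, and so does the step of a 1.2-fold lower number from compound 1 to compound 4 (0.06 log units; within the scatter) for lengthening propyl to butyl, so hydrogen, propyl and butyl cannot be told apart on this saturated chain carbon. Butyl does separate from 1-hydroxyethyl, with a 2.6-fold lower number from compound 2 to compound 4 (0.42 log units; beyond the scatter) as a modest step beyond the scatter, which makes compound 2 the only one of the four that stands clear of all the others. Adding plain chain length at this place therefore shows no clear trend, with compound 2 as the one compound outside the plain-chain group, and nothing available here explains why it stands apart.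

The compounds shown leave open whether a longer chain than butyl, or a chain ending in an amine or a carboxylic acid, would stay level with the plain chains or move away from them as compound 2 does. They also leave open whether a shorter hydroxymethyl group at this place would give a number close to that of compound 2 or close to those of the plain chains.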